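Replacing the N-aryl group with cyclohexyl

The source may hold more compounds than are shown below. What is called first, only, known or untested is meant among the compounds shown, and "the series" means these compounds.

Values in a functional assay on A549 cells (Homo sapiens) for antiproliferative activity, read by MTT assay, with a stated time of 72 h; on this read-out lower numbers stand for stronger inhibition and higher numbers for weaker inhibition
compound 1 `COc1ncc(-c2ccc3c(c2)N(c2ccc(C)cc2)C(=O)CO3)cc1NS(=O)(=O)c1ccc(F)cc1` gives 5870 nM
compound 2 `O=C1COc2ccc(-c3cnc(Cl)c(NS(=O)(=O)c4ccc(F)cc4)c3)cc2N1C1CCCCC1` gives 37900 nM
compound 3 `COc1ncc(-c2ccc3c(c2)N(c2ccc(F)cc2)C(=O)CO3)cc1NS(=O)(=O)c1ccc(F)cc1` gives 6500 nM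

In this assay compound 3 lies within the scatter of compound 1, and both stand at lower numbers than compound 2. Compound 4 `COc1ncc(-c2ccc3c(c2)N(C2CCCCC2)C(=O)CO3)cc1NS(=O)(=O)c1ccc(F)cc1` comes next, with cyclohexyl in place of 4-fluorophenyl on an amide-type nitrogen in a ring as the counted change: cyclohexyl in place of 4-fluorophenyl on an amide-type nitrogen in a ring. Going by the values given here, the one measured step (a 1.1-fold higher number from compound 1 to compound 3 (0.04 log units; within the scatter)) swaps methyl for fluoro on an aromatic carbon, so it bears only weakly on this change. Compound 2 (37900 nM) also carries cyclohexyl there but differs from compound 3 elsewhere too. A moderate rise is therefore expected in this assay (a 2.2-fold higher number from compound 3 to compound 4 (0.33 log units; beyond the scatter)). The estimate for compound 4 is 14000 nM (expected range 5000 nM to 35000 nM).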

Compound 4, half-maximal inhibitory concentration: 24600 nM
The estimate for compound 4 lay 1.8-fold (0.24 log units) below the measured number; measured number inside the range.
By their numbers in this assay, from the lowest: compounds 1 and 3 (each within the scatter of the next); then compounds 4 and 2 (each within the scatter of the next).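

In this assay, cyclohexyl on the amide-type nitrogen in a ring weakens inhibition against both aryl partners (a 3.8-fold higher number from compound 3 to compound 4 (0.58 log units; beyond the scatter); a 4.2-fold higher number from compound 1 to compound 4 (0.62 log units; beyond the scatter)), so this position separates cyclohexyl from the aryl groups, a difference that the earlier swap of methyl for fluoro did not reveal. With cyclohexyl in place, methoxy in place of chloro on an aromatic carbon stays within the scatter (a 1.5-fold lower number from compound 2 to compound 4 (0.19 log units; within the scatter)). No measured evidence here bears on the reason for these results.

Open, on these data alone, is whether a smaller alkyl such as methyl, or a chain ending in an amine or a carboxylic acid, on this nitrogen would stay near compound 1 and compound 3. Also open, as far as these compounds go, is whether chloro and methoxy would stay as close with an aryl group on this nitrogen.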